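This account rests on a few compounds, and the source may have more. Where it says the series, first, only, none or still open, it means among the compounds named here.

Among the measured compounds shown here, the three compounds measured so far share one core and differ only in the aryl group on the terminal amide. Compound 1 `CN(C)C(=O)c1cc2cnc(Nc3ccc(NC(=O)C4(C(=O)Nc5ccccc5)CC4)cc3)nc2n1C1CCCC1` carries an unsubstituted phenyl there, and in a functional assay on A549 cells (Homo sapiens) for inhibition, read by CCK-8 assay, with a stated time of 72 h, tested at 1 uM (a lower number here means less inhibition of growth, a higher number more inhibition of growth at the concentration tested), compound 1 gives 75%. Compound 2 `Cc1cccc(NC(=O)C2(C(=O)Nc3ccc(Nc4ncc5cc(C(=O)N(C)C)n(C6CCCC6)c5n4)cc3)CC2)c1` carries a 3-methylphenyl, and in this assay compound 2 gives 35.2%. Compound 3 `CN(C)C(=O)c1cc2cnc(Nc3ccc(NC(=O)C4(C(=O)Nc5ccc(Cl)cc5)CC4)cc3)nc2n1C1CCCC1` carries a 4-chlorophenyl, and in this assay compound 3 gives 24.7%. Compound 1 thus stands highest of the three, with a number 39.8 percentage points lower from compound 1 to compound 2 (beyond the scatter) and a number 50.3 percentage points lower from compound 1 to compound 3 (beyond the scatter), while a number 10.5 percentage points lower from compound 2 to compound 3 (beyond the scatter).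

Compound 4 `CN(C)C(=O)c1cc2cnc(Nc3ccc(NC(=O)C4(C(=O)Nc5ccc(C#N)cc5)CC4)cc3)nc2n1C1CCCC1` is not yet measured. Its change from compound 1 is cyano in place of hydrogen on an aromatic carbon. For the measured compounds named here, two measured steps bear on this, since both substituents placed on the phenyl of compound 1 so far lowered the inhibition by a large amount: methyl with a number 39.8 percentage points lower from compound 1 to compound 2 (beyond the scatter) and chloro with a number 50.3 percentage points lower from compound 1 to compound 3 (beyond the scatter). Going by the values given here, no measured compound carries a cyano group, so the expectation for compound 4 rests on these two analogies alone. Since compound 2 and compound 3 each fell beyond the scatter, a similar large drop in this assay is expected for compound 4, estimated as a number 45 percentage points lower from compound 1 to compound 4 (beyond the scatter). Compound 4 is therefore expected to give about 30% in this assay, within a range of 12% to 55%.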

Compound 4, percent growth inhibition at one concentration: 86.1%
Estimate against measurement, compound 4: 56.1 percentage points below; the measured number lies above the stated range.
By their numbers in this assay, from the lowest: compound 3; then compound 2; then compound 1; then compound 4.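

Cyano at this place, on the aromatic carbon para to a large group, shows that a substituent there need not lower the number in this assay: the phenyl of compound 1 takes the nitrile with a modest rise (a number 11.1 percentage points higher from compound 1 to compound 4 (beyond the scatter)), against the drops seen with methyl and chloro. Occupying the ring is therefore not what decides the outcome, since exchanging the chloro for cyano at the same place gives a large change (a number 61.4 percentage points higher from compound 3 to compound 4 (beyond the scatter)), and the 4-cyanophenyl also stands well clear of the 3-methylphenyl (a number 50.9 percentage points higher from compound 2 to compound 4 (beyond the scatter)). Compound 4 thus breaks the downward trend that compound 2 and compound 3 had suggested, so that trend cannot be read as a general penalty for substitution on this ring. Nothing available explains why the nitrile behaves so differently from the chloro at this place.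

The compounds shown leave open whether the rise belongs to the nitrile alone or would also appear with other groups at this place, such as a carboxylic acid, an amine or a trifluoromethyl group. They also leave open whether a nitrile would hold its effect where compound 2 carries its methyl, and whether the order seen at this single concentration would persist across a range of concentrations.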